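A few compounds are considered here, and "the series" means these few. Any claim that something is new, unique, unknown or untested is made for them only; others in the source may bear on it.

Compound 3 `COc1ccc(C(=O)Nc2ccccc2SC)cc1OC1CCCC1` stands at the weaker end of the two compounds with a definite number in an assay on isolated protein for inhibition of phosphodiesterase 4A (Sus scrofa); on this read-out lower numbers stand for stronger inhibition and higher numbers for weaker inhibition: compound 3 gives 1200 nM, and the nearest value is that of compound 2 `COc1ccc(C(=O)Nc2c(F)cccc2F)cc1OC1CCCC1`, which in this assay gives 70 nM, so that the step from compound 2 to compound 3 amounts to a 17-fold higher number from compound 2 to compound 3 (1.23 log units; beyond the scatter). Compound 1 `COc1ccc(C(=O)Nc2cccc(Cl)c2Cl)cc1OC1CCCC1` in this assay reaches only a limit, > 200000 nM (the limit of > 200000 nM in this assay, at which 1 of the 3 values shown sits). Compound 4 `COc1ccc(C(=O)Nc2ccncc2)cc1OC1CCCC1` differs from compound 3 in a single place: pyridin-4-yl in place of 2-(methylsulfanyl)phenyl on an amide-type nitrogen. Within the data shown here, no measured step makes this exact exchange, but every step that swaps the group on the amide-type nitrogen has been large: an at least 2800-fold lower number from compound 1 to compound 2 (3.45 log units; beyond the scatter), an at least 160-fold lower number from compound 1 to compound 3 (2.22 log units; beyond the scatter) and a 17-fold higher number from compound 2 to compound 3 (1.23 log units; beyond the scatter). A change at this position is therefore expected to move the number beyond the scatter. Because compound 2 sits well below compound 3 in the step of a 17-fold higher number from compound 2 to compound 3 (1.23 log units; beyond the scatter), a different group at this nitrogen can clearly give a lower number, and for compound 4 a lower number is expected as well, a 4.0-fold lower number from compound 3 to compound 4 (0.60 log units; beyond the scatter), though with wide uncertainty. For compound 4 in this assay the estimate is 300 nM, with a range from 50 nM to 2000 nM.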

Compound 4, half-maximal inhibitory concentration: 800 nM
The estimate for compound 4 lay 2.7-fold (0.43 log units) below the measured number, and the stated range covers the measured number.
By their numbers in this assay, from the lowest: compound 2; then compounds 4 and 3 (each within the scatter of the next). At a limit, above all of these: compound 1.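

In this assay, among these compounds, this is the first exchange on the amide-type nitrogen that stays within the scatter, a 1.5-fold lower number from compound 3 to compound 4 (0.18 log units; within the scatter), so pyridin-4-yl and 2-(methylsulfanyl)phenyl cannot be told apart here, although one ring carries a hetero atom and the other is of carbon only. The large swings at this position therefore do not apply to every exchange, while the other two steps remain large: an 11-fold higher number from compound 2 to compound 4 (1.06 log units; beyond the scatter) and an at least 250-fold lower number from compound 1 to compound 4 (2.39 log units; beyond the scatter), which leaves 2,6-difluorophenyl in compound 2 clearly apart from the pair of compounds 3 and 4 among the groups with definite numbers. Compound 1 gives a limit of the assay and not a number, so its step can be read only as a bound: the limit of > 200000 nM in this assay, at which 1 of the 4 values shown sits.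

The compounds shown leave open whether pyridin-3-yl, plain phenyl or 2-aminophenyl on this nitrogen would fall with compound 2 or with compounds 3 and 4. They also do not tell whether a single fluorine, as in 2-fluorophenyl, would be enough to give a number like that of compound 2.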